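A few compounds are considered here, and "the series" means these few. Any claim that something is new, unique, unknown or untested is made for them only; others in the source may bear on it.

Of the compounds shown here, three from this series have so far been tested in an ADME assay on MT2 cells (Homo sapiens) for cytotoxicity, read by MTT assay; a lower number here means that less compound is tolerated, a higher number that more compound is tolerated. Compound 1 `Clc1cccc(Cl)c1Cc1nnc(Nc2ccc(COCc3ccccn3)cc2)o1` did not reach a measurable number: in this assay compound 1 gives > 100000 nM, which is a limit of the measurement and not a value. The other two compounds did give numbers. Compound 2 `[O-][n+]1ccc(OCc2ccc(Nc3ncc(Cc4c(F)cccc4F)o3)cc2Cl)cc1` gives 1700 nM in this assay. Compound 3 `Fc1cccc(F)c1Cc1cnc(Nc2ccc(Oc3cccnc3)c(Br)c2)o1` gives 7500 nM in this assay. Compound 1 therefore stands at the most tolerated end of what has been seen, sitting at the limit of > 100000 nM in this assay, at which 1 of the 3 values shown sits.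

The next compound to be tested is compound 4 `Clc1cccc(Cl)c1Cc1nnc(Nc2ccc(COCc3cccnc3)cc2)o1`. It has the same atoms as compound 1, joined differently: pyridin-3-yl in place of pyridin-2-yl on a saturated chain carbon bound to an oxygen on a saturated carbon. The pyridine ring keeps its single nitrogen, its one hydrogen-bond acceptor and its lack of charge; only the point at which the ring is attached to the saturated chain carbon changes.

Going by the values given here, no step between measured compounds of this kind is available, so the expectation rests on compound 1 alone. A shift of this size is expected to stay within the usual scatter, in no particular direction, so the step from compound 1 to compound 4 is estimated at a number no higher from compound 1 to compound 4 (the limit leaves the size open). Compound 4 is accordingly expected to give about 100000 nM in this assay, in a range from 30000 nM to 300000 nM, and it may well again return only a limit.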

Compound 4, half-maximal cytotoxic concentration: 81000 nM
Estimate against measurement, compound 4: 1.2-fold (0.09 log units) above, and the stated range covers the measured number.
By their numbers in this assay, from the lowest: compound 2; then compound 3; then compound 4. At a limit, above all of these: compound 1.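

Compound 1 and compound 4 form the only pair shown that differs in one place, so this change can now be read directly: in this assay, pyridin-3-yl in place of pyridin-2-yl on a saturated chain carbon bound to an oxygen on a saturated carbon gives an at least 1.2-fold lower number from compound 1 to compound 4 (0.09 log units; that floor lies within the scatter). Compound 4 gives 81000 nM, so this arrangement of the same atoms has an actual number in the assay, and the pair offers no sign that moving the attachment point of the pyridine ring matters much for how much compound the cells tolerate. The full size of the step cannot be read, since compound 1 is held only by a limit and not by a number: the limit of > 100000 nM in this assay, at which 1 of the 4 values shown sits.

A single pair cannot show whether the same swap would behave alike on a different core, or whether the small step seen here holds beyond the core of compound 1. On these data alone, it also remains open how a pyridin-4-yl group or a plain phenyl ring, which has no ring nitrogen, would fare at this same place.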